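This account rests on a few compounds, and the source may have more. Where it says the series, first, only, none or still open, it means among the compounds named here.

Measured compounds:
- compound 1, `Cc1cccc(Cn2c(CN3CCN(C(=O)c4ccc(C(C)C)cc4)CC3)nc3ccccc32)c1`: in an assay on isolated protein for inhibition of aldehyde dehydrogenase 1A1 (Homo sapiens), read by spectrophotometry, tested at 10 uM (a lower number here means less inhibition, a higher number more inhibition at the concentration tested (going by the name of the read-out)), compound 1 gives 67.6%
- compound 2, `O=C(C1CC1)N1CCN(Cc2nc3ccccc3n2Cc2cccc(F)c2)CC1`: compound 2 gives 27.2%
- compound 3, `CC(C)CCn1c(CN2CCN(C(=O)C3CC3)CC2)nc2ccccc21`: compound 3 gives 70%

Compound 1 stands second highest of the three numbers. Its nearest neighbour is compound 3, whose number lies within the scatter of that of compound 1, so no order between the two is claimed. Compound 2 lies beyond the scatter below compound 1. Among the measured compounds shown here, the one step measured, a number 42.8 percentage points higher from compound 2 to compound 3 (beyond the scatter), concerns the group on the saturated chain carbon bound to the aromatic nitrogen of the shared core and leaves the rest of the molecule untouched.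

Compound 4, `Cc1cccc(Cn2c(CN3CCN(C(=O)c4ccc(C#N)cc4)CC3)nc3ccccc32)c1`, is not yet measured. It differs from compound 1 by cyano in place of isopropyl on an aromatic carbon, on the carbonyl-bearing ring. For the measured compounds named here, no measured step touches that ring: compounds 2 and 3 carry a cyclopropyl on the carbonyl instead and no step to compound 1 is given for them, so the measured step bears on compound 4 only indirectly. With no change at the position the step 2>3 probes, the number of compound 1 is taken as the anchor, and the expected step of a number 12.6 percentage points lower from compound 1 to compound 4 (beyond the scatter) is estimated to lie close to the scatter, with a wide range. For compound 4 the estimate in this assay is 55%, between 25% and 80%.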

Compound 4, a percentage reported as inhibition, at one concentration (the size of the read-out at that concentration, not a potency): 20.8%
Compound 4: middle estimate off by 34.2 percentage points, on the high side, outside the stated range (below it).
By their numbers in this assay, from the lowest: compounds 4 and 2 (each within the scatter of the next); then compounds 1 and 3 (each within the scatter of the next).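

The ring bearing the carbonyl proves to be a sensitive place in this assay: cyano in place of isopropyl on an aromatic carbon, para to a large group, gives a number 46.8 percentage points lower from compound 1 to compound 4 (beyond the scatter) and is the only step shown on that ring. Together with a number 42.8 percentage points higher from compound 2 to compound 3 (beyond the scatter) on the chain at the aromatic nitrogen, it shows that two separate places in the series can each carry a large step. No accompanying data bear on what lies behind this change.

Still open, on these data alone, is whether the drop goes with losing isopropyl or with gaining cyano, as only these two groups appear at this carbon. A methoxy group, a chlorine or a tert-butyl group at the same carbon would help to separate those two readings.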